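Propyl in place of cyclopropyl and cytotoxicity on J774.1 cells

This account rests on a few compounds, and the source may have more. Where it says the series, first, only, none or still open, it means among the compounds named here.

Measured compounds:
Compound 1 `CCCn1cc(C(=O)NCc2ccco2)c(=O)c2cc(F)c(N3CCC(C(N)=O)CC3)cc21` gives 56900 nM in an ADME assay on J774.1 cells (Mus musculus) for cytotoxicity, read by resazurin assay, with a stated time of 48 h; on this read-out higher numbers stand for weaker inhibition and lower numbers for stronger inhibition.
Compound 2 `NC(=O)C1CCN(c2cc3c(cc2F)c(=O)c(C(=O)NCc2ccco2)cn3C2CC2)CC1` gives only a limit in this assay, > 100000 nM.
Compound 3 `NC(=O)C1CCN(c2cc3c(cc2F)c(=O)c(C(=O)O)cn3C2CC2)CC1` likewise gives only a limit in this assay, > 100000 nM.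

Two of the three values therefore sit at the same floor, namely (the limit of > 100000 nM in this assay, at which 2 of the 3 values shown sit). Compound 2 and compound 1 differ by propyl in place of cyclopropyl on an aromatic nitrogen, and this change brought an at least 1.7-fold lower number from compound 2 to compound 1 (0.24 log units; that floor lies within the scatter); with one end of the step being a limit, its true size is not known, and the floor of the step lies within the scatter. Compound 2 and compound 3 differ in their cores by hydroxy in place of ((furan-2-yl)methyl)amino on a carbonyl carbon, and that step reads a step that the two limits leave unreadable from compound 2 to compound 3, since both ends are limits.

Compound 4 `CCCn1cc(C(=O)O)c(=O)c2cc(F)c(N3CCC(C(N)=O)CC3)cc21` is not yet measured. It differs from compound 3 by propyl in place of cyclopropyl on an aromatic nitrogen, the same kind of change as that from compound 2 to compound 1, though around the place the neighbour is a carboxy group rather than a ((furan-2-yl)methyl)carbamoyl group. Because the measured change gave only an at least 1.7-fold lower number from compound 2 to compound 1 (0.24 log units; that floor lies within the scatter), whose floor lies within the scatter, compound 4 is expected to show a step of about a number no higher from compound 3 to compound 4 (the limit leaves the size open) from compound 3, which may itself be reported only as a limit. The estimate for compound 4 in this assay is 100000 nM, with a range from 45000 nM to 250000 nM.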

Compound 4, half-maximal inhibitory concentration: > 100000 nM
Compound 4: a limit, no number; the forecaster's own chance of this, stated with the estimate: 60%; the middle value lies on the limit itself.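

In this assay compound 4 gives > 100000 nM, which is a limit and not a number. Compound 3 also stands only at a limit, so the step for propyl in place of cyclopropyl with the carboxy group present cannot be read, and neither can any other step with a limit at both ends; the compounds therefore neither show that the change carries from one core to the other nor show that it fails to. The only readable steps are an at least 1.7-fold lower number from compound 2 to compound 1 (0.24 log units; that floor lies within the scatter) for the propyl change and an at least 1.7-fold higher number from compound 1 to compound 4 (0.24 log units; that floor lies within the scatter) for hydroxy in place of ((furan-2-yl)methyl)amino, and each gives only a floor within the scatter, so neither establishes a real difference, and the shared limit keeps the comparison between cores from going further: the limit of > 100000 nM in this assay, at which 3 of the 4 values shown sit.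

On these data alone, the true size of each step ending at the limit stays open, including whether the propyl change does anything at all when the carboxy group is present. Also open, as far as these compounds go, is what a longer chain such as butyl on the aromatic nitrogen, or a benzyl group in place of the (furan-2-yl)methyl group on the amide, would give in this assay.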